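Bromo in Place of Nitro: A Cytotoxicity Estimate

The source may report more compounds than this note shows. Statements on the series, on what has been measured and on what is new or still open speak of the compounds shown alone.

Two related compounds have been tested so far in an ADME assay on BJ cells (Homo sapiens) for cytotoxicity, with a stated time of 72 h; on this read-out higher numbers stand for an effect only at larger amounts of compound and lower numbers for an effect already at smaller amounts. Compound 1 `COc1ccc(-c2nc3c(c(C)nn3-c3ccccc3)c(-c3ccccc3O)c2C#N)cc1` gives > 23000 nM, which is a limit of the assay and not a number. On these data alone, compound 2 `CCc1ccc(-c2nc3c(c(C)nn3-c3ccccc3)c(-c3ccccc3[N+](=O)[O-])c2C#N)cc1` gives > 20000 nM, which is also a limit, so its exact position on the scale is unknown.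

Compound 3 `CCc1ccc(-c2nc3c(c(C)nn3-c3ccccc3)c(-c3ccccc3Br)c2C#N)cc1` differs from compound 2 in one place: bromo in place of nitro on an aromatic carbon. The 2-nitrophenyl of compound 2 becomes 2-bromophenyl in compound 3. Within the data shown here, no measured pair shows the effect of this swap, so the expectation rests only on the limit of compound 2 at > 20000 nM. In this assay, no change beyond the usual scatter is expected, and no direction is favoured. The expected change is a number no higher from compound 2 to compound 3 (the limit leaves the size open). Compound 3 is estimated at 20000 nM, with an expected range from 7000 nM to 45000 nM.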

Compound 3, half-maximal effective concentration: > 20000 nM
Compound 3 ended at the assay's limit (the forecaster's own chance of this, stated with the estimate: 75%); the middle value sits exactly at the limit.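

No step can be read from compound 2 to compound 3 in this assay, because both values are limits of the assay and not numbers: the limit of > 20000 nM in this assay, at which 2 of the 3 values shown sit. The compounds shown leave open where each one truly sits on the scale, and whether bromo in place of nitro changes the read-out at all.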